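Compound 4: a smaller group on the carbonyl carbon

A few compounds are considered here, and "the series" means these few. Any claim that something is new, unique, unknown or untested is made for them only; others in the source may bear on it.

In an ADME assay on HepG2 2.2.15 cells (Homo sapiens) for cytotoxicity (on this read-out lower numbers stand for higher toxicity in this test and higher numbers for lower toxicity in this test), compound 1 `O=CCc1c(-c2ccccc2Cl)c2cc(Cl)ccc2[nH]c1=O` gives 120000 nM and compound 2 `O=C(CCOc1ccccc1)OCCc1c(-c2ccccc2Cl)c2cc(Cl)ccc2[nH]c1=O` gives 46000 nM. Compound 3 `COc1ccc(/C=C/C(=O)OCCc2c(-c3ccccc3Cl)c3cc(Cl)ccc3[nH]c2=O)cc1OC` reads > 1200000 nM, which is a limit and not a number. Compound 4 `C/C=C(\C)C(=O)OCCc1c(-c2ccccc2Cl)c2cc(Cl)ccc2[nH]c1=O` carries 1-methylprop-1-en-1-yl in place of 2-(3,4-dimethoxyphenyl)ethenyl on a carbonyl carbon. Going by the values given here, the one measured step bearing on this is an at least 26-fold higher number from compound 2 to compound 3 (1.41 log units; beyond the scatter), which brought that same 2-(3,4-dimethoxyphenyl)ethenyl in. With that group gone again, a large step towards a lower number is expected in this assay, an at least 12-fold lower number from compound 3 to compound 4 (1.07 log units; beyond the scatter). For compound 4 the expected value is 100000 nM, with an estimated range from 30000 nM to 500000 nM.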

Compound 4, half-maximal cytotoxic concentration: 350000 nM
For compound 4 the middle estimate is 3.5-fold (0.54 log units) below the measured one; the range from low to high includes it.
By their numbers in this assay, from the lowest: compound 2; then compound 1; then compound 4. At a limit, above all of these: compound 3.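

In this assay, a group with no ring on the carbonyl carbon still reads high: 1-methylprop-1-en-1-yl gives a 7.6-fold higher number from compound 2 to compound 4 (0.88 log units; beyond the scatter), and against the aldehyde side chain of the core it gives a 2.9-fold higher number from compound 1 to compound 4 (0.46 log units; beyond the scatter). High numbers at this position therefore do not depend on 2-(3,4-dimethoxyphenyl)ethenyl, even though removing it gives an at least 3.4-fold lower number from compound 3 to compound 4 (0.53 log units; beyond the scatter). That step starts from a limit for compound 3, not a number: the limit of > 1200000 nM in this assay, at which 1 of the 4 values shown sits.

From the compounds shown here alone, how far compound 3 truly lies from compound 4 stays open. So does whether an amine or a carboxylic acid on this carbonyl carbon would keep the number high.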